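Extending the amine chain in a benzoxazole-free account of compound 4

The source may hold more compounds than are shown below. What is called first, only, known or untested is meant among the compounds shown, and "the series" means these compounds.

Compound 1 `Cc1cc(-c2nc3ccccc3o2)ccc1NC(=O)CN1CCN(CCCN(C)C)CC1`: 2160 nM
Compound 2 `CN(C)CCCN1CCN(CC(=O)Nc2ccc(-c3nc4cc(Cl)ccc4o3)cc2)CC1`: 1250 nM
Compound 3 `Cc1cc(-c2nc3cc(Cl)ccc3o2)ccc1NC(=O)CN1CCN(CCN(C)C)CC1`: 3880 nM

Of the compounds shown here, three have been measured in a functional assay on HepG2 cells (Homo sapiens) for cytotoxicity, read by MTT assay, with a stated time of 24 h; on this read-out higher numbers stand for weaker inhibition and lower numbers for stronger inhibition. Compound 3 gives the highest of the three numbers, with 3880 nM. Its nearest neighbour is compound 1, whose number is lower but within the scatter of the two; compound 2, with 1250 nM, lies beyond the scatter, so compound 3 is the weaker of that pair.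

Compound 4 `Cc1cc(-c2nc3cc(Cl)ccc3o2)ccc1NC(=O)CN1CCN(CCCN(C)C)CC1` differs from compound 3 in one place: (dimethylamino)methyl in place of dimethylamino on a saturated chain carbon, two bonds along the chain from an amine nitrogen in a ring. Compound 1 carries the same 3-(dimethylamino)propyl chain as compound 4, and compound 2 carries it too, and neither gives a higher number than compound 3. Within the data shown here, with no directly comparable step in hand, the account expects the change from compound 3 to compound 4 to give at most a modest lowering of the number in this assay, estimated as a 1.6-fold lower number from compound 3 to compound 4 (0.21 log units; within the scatter), and possibly none beyond the scatter. For compound 4 the estimated value is 2400 nM, within a range from 1000 nM to 5500 nM.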

Compound 4, half-maximal inhibitory concentration: 11200 nM
For compound 4 the middle estimate is 4.7-fold (0.67 log units) below the measured one, outside the stated range (above it).
By their numbers in this assay, from the lowest: compounds 2, 1 and 3 (each within the scatter of the next, the first and the last beyond it); then compound 4.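

In this assay, (dimethylamino)methyl in place of dimethylamino on a saturated chain carbon, two bonds along the chain from an amine nitrogen in a ring, gives a 2.9-fold higher number from compound 3 to compound 4 (0.46 log units; beyond the scatter), so the number at this position depends on chain length when the chloro and methyl groups are both present. With the 3-(dimethylamino)propyl chain in place, adding either aromatic group also raises the number: methyl in place of hydrogen on an aromatic carbon gives a 9.0-fold higher number from compound 2 to compound 4 (0.95 log units; beyond the scatter), and chloro in place of hydrogen on an aromatic carbon gives a 5.2-fold higher number from compound 1 to compound 4 (0.71 log units; beyond the scatter). Nothing available accounts for these rises.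

Going by these compounds, whether the same chain change raises the number without the chloro or methyl group remains open. So does what a longer chain such as 4-(dimethylamino)butyl, or a morpholine in place of dimethylamino, would give.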